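This account rests on a few compounds, and the source may have more. Where it says the series, first, only, none or still open, it means among the compounds named here.

Measured so far in a functional assay on SF-268 cells (Homo sapiens) for inhibition, read by sulforhodamine B assay, with a stated time of 48 h; on this read-out lower numbers stand for stronger inhibition of growth and higher numbers for weaker inhibition of growth:
compound 1, `COc1cc(-c2nn(-c3cccc(NC(=O)c4ccc(Cl)c(C(F)(F)F)c4)c3)cc2-c2ccncc2)ccc1Cl`: 4860 nM
compound 2, `O=C(Nc1cccc(-n2cc(-c3ccncc3)c(-c3ccc(Cl)c(O)c3)n2)c1)Nc1ccc(Cl)c(C(F)(F)F)c1`: 1060 nM

Compound 1 gives the higher of the two numbers; compound 2 gives the lower one, and the gap lies beyond the scatter. Compound 3, `COc1cc(-c2nn(-c3cccc(NC(=O)Nc4ccc(Cl)c(Cl)c4)c3)cc2-c2ccncc2)ccc1Cl`, is not yet measured. It departs from compound 1 in one place: (3,4-dichlorophenyl)amino in place of 4-chloro-3-(trifluoromethyl)phenyl on a carbonyl carbon. Compound 2 also has an amino group bound to its carbonyl carbon and, with 1060 nM, sits below compound 1, though compound 2 differs in other places as well. A downward step is therefore expected, a 3.0-fold lower number from compound 1 to compound 3 (0.48 log units; beyond the scatter), of moderate size. For compound 3 the estimate in this assay is 1600 nM, within 500 nM to 5000 nM.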

Compound 3, concentration for 50% growth inhibition: 1510 nM
Beside the measured number, compound 3's estimate is 1.1-fold (0.03 log units) above it, within the range that was stated.
By their numbers in this assay, from the lowest: compounds 2 and 3 (each within the scatter of the next); then compound 1.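

In this assay, (3,4-dichlorophenyl)amino in place of 4-chloro-3-(trifluoromethyl)phenyl on the carbonyl carbon gives a 3.2-fold lower number from compound 1 to compound 3 (0.51 log units; beyond the scatter) with the rest of the molecule unchanged. This position therefore responds to change, but the swap adds an amino group and replaces trifluoromethyl with chlorine at once, so this single pair cannot separate the two. Nothing available accounts for the step.

Open, from the compounds shown here alone, is whether 4-chloro-3-(trifluoromethyl)phenylamino on the core of compound 1 would give the same reading, which would isolate the amino group. Going by these compounds, how a methylene link in place of that amino group would read also remains open.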